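The source may report more compounds than this note shows. Statements on the series, on what has been measured and on what is new or still open speak of the compounds shown alone.

Measured compounds:

Compound 1 `N=C(S)CCn1nc(-c2ccccc2)ccc1=O`: 53.7%
Compound 2 `N=C(S)Cn1nc(-c2ccccc2)ccc1=O`: 5.5%
Compound 3 `N=C(S)CCCCn1nc(-c2ccccc2)ccc1=O`: 33.8%

In a functional assay on the whole organism (stomach) for inhibition, with Rattus norvegicus as the target, at a dose of 100 mg/kg by the intraduodenal route (on this read-out lower numbers stand for less inhibition and higher numbers for more inhibition at the one dose given (going by the name of the read-out)), compound 3 stands second highest of the three; compound 1 is nearer, compound 2 furthest. The steps among them are a number 19.9 percentage points lower from compound 1 to compound 3 (beyond the scatter) and a number 28.3 percentage points higher from compound 2 to compound 3 (beyond the scatter), while a number 48.2 percentage points lower from compound 1 to compound 2 (beyond the scatter) is the largest step seen.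

Compound 4 `CN(C)C(=S)CCn1nc(-c2ccccc2)ccc1=O` is not yet measured. It differs from compound 3 by a group of 5 heavy atoms (3 carbon, 1 nitrogen, 1 sulfur; no ring) in place of a group of 5 heavy atoms (3 carbon, 1 nitrogen, 1 sulfur; no ring), on a saturated chain carbon, two bonds along the chain from an aromatic nitrogen. The two compounds have the same atoms joined differently: the group that leaves carries two hydrogen-bond donors, the group that enters none. Among the compounds with values here, no measured step changes donors, so only the chain steps bear on it. Within the data shown here, compound 4 has the same two-carbon spacing as compound 1, whose value is the highest here, but the loss of both donors has no precedent among the three. A step in this assay of uncertain direction is therefore expected, probably within or near the scatter, as a number 1.2 percentage points higher from compound 3 to compound 4 (within the scatter). The estimate for compound 4 is 35%, with a range from 10% to 60%.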

Compound 4, a percentage reported as inhibition, in the whole organism at one dose (the size of the read-out at that dose, not a potency): 46%
For compound 4 the middle estimate is 11 percentage points below the measured one; low and high end bracket the measured number.
By their numbers in this assay, from the lowest: compound 2; then compound 3; then compounds 4 and 1 (each within the scatter of the next).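

In this assay, the step of a number 7.7 percentage points lower from compound 1 to compound 4 (within the scatter) shows that, on the chain of compound 1, an end group without hydrogen-bond donors gives a result that cannot be told apart from the one with donors. The steps of a number 12.2 percentage points higher from compound 3 to compound 4 (beyond the scatter) and a number 40.5 percentage points higher from compound 2 to compound 4 (beyond the scatter) are clear, but each changes the chain and the end group together, so neither can be assigned to one change alone. Nothing measured here explains these numbers.

On these data alone, it remains open whether the dimethylamino end group would behave the same way on the shorter or longer chain of compound 2 or compound 3. The effect of a single methyl on that nitrogen, a ring amine such as piperidine, or an oxygen amide in place of the sulfur-bearing group is also unknown.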